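Sulfonyl aryl swap in the cytotoxicity series

The source may hold more compounds than are shown below. What is called first, only, known or untested is meant among the compounds shown, and "the series" means these compounds.

Compound 3 `COc1ccccc1S(=O)(=O)Nc1ccc(-c2nc3ccccc3o2)cc1` stands at > 100000 nM in an ADME assay on HEK293 cells (Homo sapiens) for cytotoxicity, read by resazurin assay, with a stated time of 48 h (on this read-out lower numbers stand for higher toxicity in this test and higher numbers for lower toxicity in this test), as a limit of the assay. Compound 2 `C=Cc1ccc(S(=O)(=O)Nc2ccc(-c3nc4ccccc4o3)cc2)cc1` gives > 100000 nM as a limit too. For the measured compounds named here, compound 1 `Cc1ccc(S(=O)(=O)Nc2ccc(-c3nc4ccccc4o3)cc2)cc1` gives 88000 nM as the only actual number so far. Compound 4 `Cc1cccc(S(=O)(=O)Nc2ccc(-c3nc4ccccc4o3)cc2)c1` carries 3-methylphenyl in place of 2-methoxyphenyl on a sulfonyl sulfur and so has 3-methylphenyl in place of 2-methoxyphenyl on a sulfonyl sulfur. Going by the values given here, three measured steps bear on this change: an at least 1.1-fold higher number from compound 1 to compound 3 (0.05 log units; that floor lies within the scatter) and an at least 1.1-fold higher number from compound 1 to compound 2 (0.05 log units; that floor lies within the scatter) both have floors within the scatter, while a step that the two limits leave unreadable from compound 2 to compound 3 cannot be read. A step of an at least 1.0-fold lower number from compound 3 to compound 4 (0.02 log units; that floor lies within the scatter) is expected to stay within the scatter, with no direction favoured. Compound 4 is estimated at 95000 nM with a range of 50000 nM to 140000 nM and may also return only a limit.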

Compound 4, half-maximal cytotoxic concentration: > 100000 nM
Compound 4 ended at the assay's limit; the forecaster's own chance of this, stated with the estimate: 55%; middle value at least 1.0-fold (0.02 log units) from the limit.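

Compound 4 adds 3-methylphenyl as a third group on the sulfonyl sulfur that returns only a limit in this assay, so neither the oxygen of 2-methoxyphenyl nor the vinyl of compound 2 is needed to reach it. With 3-methylphenyl in place of 4-methylphenyl there is an at least 1.1-fold higher number from compound 1 to compound 4 (0.05 log units; that floor lies within the scatter), so moving the methyl group has no readable consequence here. The steps among compound 2, compound 3 and compound 4 cannot be read: the limit of > 100000 nM in this assay, at which 3 of the 4 values shown sit.

On these data alone, whether any group on the sulfonyl sulfur gives a clearly lower number remains open. An amine or a carboxylic acid on that aryl ring would test this.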